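Terminal amine swaps at the chain end of the shared core

This account rests on a few compounds, and the source may have more. Where it says the series, first, only, none or still open, it means among the compounds named here.

Compound 3 `CCN1CCN(CCCOc2cc3ncnc(Nc4ccc(C#N)cc4)c3cc2OC)CC1` gives 16000 nM in a functional assay on A549 cells (Homo sapiens) for antiproliferative activity, read by MTT assay, with a stated time of 72 h (on this read-out higher numbers stand for weaker inhibition and lower numbers for stronger inhibition), the lowest of the two numbers in hand. Compound 2 `CCOC(=O)C1CCN(CCCOc2cc3ncnc(Nc4ccc(C#N)cc4)c3cc2OC)CC1` gives 89900 nM in this assay. Compound 1 `COc1cc2c(Nc3ccc(C#N)cc3)ncnc2cc1OCCCN1CCCCC1CCO` gives > 100000 nM in this assay, which is a limit of the assay rather than a number. Every measured step exchanges the whole group at the chain end: a 5.6-fold lower number from compound 2 to compound 3 (0.75 log units; beyond the scatter), an at least 6.2-fold lower number from compound 1 to compound 3 (0.79 log units; beyond the scatter) and an at least 1.1-fold lower number from compound 1 to compound 2 (0.04 log units; that floor lies within the scatter). Compound 4 `COc1cc2c(Nc3ccc(C#N)cc3)ncnc2cc1OCCCN1CCN(c2ccncc2)CC1` differs from compound 3 by pyridin-4-yl in place of ethyl on an amine nitrogen in a ring. Going by the values given here, none of the measured steps alters a substituent on the amine nitrogen in the ring while keeping the ring itself; they show only that replacing the terminal amine shifts the read-out by modest amounts in this assay. Among the compounds with values here, with no closer precedent, the expected step is a 1.6-fold higher number from compound 3 to compound 4 (0.19 log units; within the scatter), a change within or near the scatter and with no direction favoured. Compound 4 is therefore estimated at 25000 nM, in the range 6000 nM to 90000 nM.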

Compound 4, half-maximal inhibitory concentration: 25500 nM
Compound 4: the middle estimate sits 1.0-fold (0.01 log units) below what was measured; measured number inside the range.
By their numbers in this assay, from the lowest: compounds 3 and 4 (each within the scatter of the next); then compound 2. At a limit, above all of these: compound 1.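

Going by these compounds alone, this is the first step that keeps the ring and changes only the group on its amine nitrogen: pyridin-4-yl in place of ethyl gives a 1.6-fold higher number from compound 3 to compound 4 (0.20 log units; within the scatter), so in this assay this larger aromatic group cannot be told apart from ethyl at this position. The advantage over the ester-bearing amine persists with the new group, with 4-(pyridin-4-yl)piperazin-1-yl in place of 4-(ethoxycarbonyl)piperidin-1-yl giving a 3.5-fold lower number from compound 2 to compound 4 (0.55 log units; beyond the scatter). The step of an at least 3.9-fold lower number from compound 1 to compound 4 (0.59 log units; beyond the scatter) gives only a floor, since compound 1 stands at a limit and not at a number: the limit of > 100000 nM in this assay, at which 1 of the 4 values shown sits.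

Still open, from the compounds shown here alone, is how phenyl, with no ring nitrogen, or pyridin-2-yl would read on that amine nitrogen. Also open, going by these compounds, is whether a morpholin-4-yl group or a shorter chain would give lower numbers.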